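Two Inactive Compounds and a Diallylamino Change

This account rests on a few compounds, and the source may have more. Where it says the series, first, only, none or still open, it means among the compounds named here.

Compound 1 (`O=C1CSC(c2cccc(Br)c2)N1c1nccs1`) gives > 50000 nM
Compound 2 (`CCN(CC)C(=O)c1cccc(C2SCC(=O)N2c2ccccc2OC)c1`) gives > 50000 nM

Both entries are limits of a functional assay on A549 cells (Homo sapiens) for antiproliferative activity, read by sulforhodamine B assay, with a stated time of 48 h (on this read-out lower numbers stand for stronger inhibition and higher numbers for weaker inhibition), and not numbers. Compound 2 therefore has no exact position, and it shares with compound 1 (the limit of > 50000 nM in this assay, at which 2 of the 2 values shown sit). Compound 3 (`C=CCN(CC=C)C(=O)c1cccc(C2SCC(=O)N2c2ccccc2OC)c1`) differs from compound 2 in one place: diallylamino in place of diethylamino on a carbonyl carbon. This puts diallylamino in place of diethylamino on a carbonyl carbon. No measured step sizes this change, so no step beyond the scatter is expected in this assay. The expected step is an at least 1.2-fold lower number from compound 2 to compound 3 (0.09 log units; that floor lies within the scatter) in size. Compound 3 is expected at 40000 nM within an estimated range of 15000 nM to 50000 nM.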

Compound 3, half-maximal inhibitory concentration: > 50000 nM
Compound 3 was reported as a limit (the forecaster's own chance of this, stated with the estimate: 70%); middle value at least 1.2-fold (0.09 log units) from the limit.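

Compound 2 and compound 3 both stand as limits in this assay, so no step can be read between them. The compounds shown leave open whether diallylamino in place of diethylamino changes activity at all.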